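Working notes: dimethylamino in place of nitro

The source may hold more compounds than are shown below. What is called first, only, known or untested is meant among the compounds shown, and "the series" means these compounds.

Compound 1 `C/C(=C\c1ccccc1)C(=O)/C=C/c1ccc([N+](=O)[O-])cc1` gives 26000 nM in an ADME assay on J774.A1 cells (Mus musculus) for cytotoxicity, read by MTT assay, with a stated time of 48 h; on this read-out higher numbers stand for lower toxicity in this test and lower numbers for higher toxicity in this test. Compound 2 `C/C(=C\c1ccccc1)C(=O)/C=C/c1ccc(N(C)C)cc1` gives 20200 nM in this assay; the step of a 1.3-fold lower number from compound 1 to compound 2 (0.11 log units; within the scatter) goes with the change (dimethylamino in place of nitro on an aromatic carbon). Compound 3 `C/C(=C\c1ccc(N(C)C)cc1)C(=O)/C=C/c1ccc([N+](=O)[O-])cc1` gives 967000 nM in this assay, the step being a 37-fold higher number from compound 1 to compound 3 (1.57 log units; beyond the scatter) for (dimethylamino in place of hydrogen on an aromatic carbon), which is also how the core of compound 3 differs from the core of compound 1. Compound 4 `C/C(=C\c1ccc(N(C)C)cc1)C(=O)/C=C/c1ccc(N(C)C)cc1` is not yet measured in this assay; it differs from compound 3 by dimethylamino in place of nitro on an aromatic carbon, the same change as between compound 1 and compound 2, seen twice among these four compounds. Because the step of a 1.3-fold lower number from compound 1 to compound 2 (0.11 log units; within the scatter) was within the scatter, the step from compound 3 to compound 4 in this assay is expected to be small, about a 1.2-fold lower number from compound 3 to compound 4 (0.08 log units; within the scatter). Compound 4 is therefore estimated at 800000 nM, between 300000 nM and 2500000 nM. One prior instance gives this expectation limited footing.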

Compound 4, half-maximal cytotoxic concentration: 10000 nM
Beside the measured number, compound 4's estimate is 80-fold (1.90 log units) above it; measured number below the stated range.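

In this assay, dimethylamino in place of nitro on an aromatic carbon does not carry from one core to the other, the new step being a 97-fold lower number from compound 3 to compound 4 (1.99 log units; beyond the scatter): the same change on two cores in this assay, a 1.3-fold lower number (0.11 log units; within the scatter) from compound 1 to compound 2 and a 97-fold lower number (1.99 log units; beyond the scatter) from compound 3 to compound 4, 75-fold (1.88 log units) apart, beyond the scatter of two such steps. Dimethylamino in place of hydrogen on an aromatic carbon does not carry either, the new step being a 2.0-fold lower number from compound 2 to compound 4 (0.31 log units; beyond the scatter): the same change on two cores in this assay, a 37-fold higher number (1.57 log units; beyond the scatter) from compound 1 to compound 3 and a 2.0-fold lower number (0.31 log units; beyond the scatter) from compound 2 to compound 4, 75-fold (1.88 log units) apart, beyond the scatter of two such steps. Within these four compounds the size of each step depends on the core that carries it, but this does not show why, and it sets no rule for other compounds in the series.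

Going by these compounds, it remains open whether compound 3 stands alone in this respect. Methoxy or chlorine in place of its nitro could show whether the large step from compound 3 to compound 4 is specific to nitro.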